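The source may hold more compounds than are shown below. What is called first, only, known or untested is meant among the compounds shown, and "the series" means these compounds.

Measured in an ADME assay on liver (Mesocricetus auratus) for metabolic stability, using microsomes; on this read-out lower numbers stand for slow clearance and higher numbers for fast clearance:
- compound 1 `N#Cc1ccc(C2CCN(C(=O)Nc3cc(-c4ccccn4)n[nH]3)CC2)cc1`: 80.8 mL.min-1.g-1
- compound 2 `COc1ccccc1C(=O)Nc1[nH]nc(-c2ccccn2)c1C1CC1`: > 100 mL.min-1.g-1

Among the measured compounds shown here, compound 1 gives the only number and lies on the fast side of the read-out. For compound 2 the result is a limit of the assay and not a number.

Compound 3 `O=C(Nc1cc(-c2ccccn2)n[nH]1)N1CCC(c2ccc(Cl)cc2)CC1` has chloro in place of cyano on an aromatic carbon of compound 1, 4-cyanophenyl to 4-chlorophenyl (chloro in place of cyano on an aromatic carbon). For the measured compounds named here, no measured step covers this change. In this assay a small rise, within the scatter, is expected: a 1.1-fold higher number from compound 1 to compound 3 (0.06 log units; within the scatter). For compound 3 the estimate is 92 mL.min-1.g-1, with an expected range of 55 mL.min-1.g-1 to 100 mL.min-1.g-1.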

Compound 3, intrinsic clearance in microsomes: 43.8 mL.min-1.g-1
Compound 3: the middle estimate sits 2.1-fold (0.32 log units) above what was measured; the whole stated range lies above it.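

In this assay, chloro in place of cyano on an aromatic carbon gives the first step read in this series: a 1.8-fold lower number from compound 1 to compound 3 (0.27 log units; within the scatter). At this place, para to a large group, the change from 4-cyanophenyl to 4-chlorophenyl therefore stays inside the usual scatter. Compound 2 offers no comparison, and its result is a limit of the assay, not a number: the limit of > 100 mL.min-1.g-1 in this assay, at which 1 of the 3 values shown sits.

On these data alone, whether an amine or a carboxylic acid on the same aromatic carbon would give a step beyond the scatter remains open. So does the effect of changes elsewhere on the core of compound 1.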